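The source may hold more compounds than are shown below. What is called first, only, known or untested is meant among the compounds shown, and "the series" means these compounds.

Compound 1 `CC(=O)OC[C@H]1O[C@@H](CC(=O)/C=C/c2cccnc2)[C@H](OC(C)=O)[C@@H](OC(C)=O)[C@@H]1OC(C)=O`: 4.17 nM
Compound 2 `COc1cc(/C=C/C(=O)C[C@@H]2O[C@H](COC(C)=O)[C@@H](OC(C)=O)[C@H](OC(C)=O)[C@H]2OC(C)=O)cc(OC)c1OC`: "not determined" (no result reported)
Compound 3 `CC(=O)OC[C@H]1O[C@@H](CC(=O)/C=C/c2ccc([N+](=O)[O-])cc2)[C@H](OC(C)=O)[C@@H](OC(C)=O)[C@@H]1OC(C)=O`: "not determined" (no result reported)

Three compounds share one acetylated sugar core carrying an unsaturated ketone chain and differ only in the aromatic group at its end. In an ADME assay on cells (Epithelial cell, Homo sapiens) for cytotoxicity, read by MTT assay, with a stated time of 24 h (a higher number here means that more compound is tolerated, a lower number that less compound is tolerated), compound 1 gives 4.17 nM. In this assay compound 2 gives "not determined" (no result reported), and compound 3 gives "not determined" (no result reported), so compound 1 is the only point of reference among the measured set.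

Compound 4 `CC(=O)OC[C@H]1O[C@@H](CC(=O)/C=C/c2ccc(C(F)(F)F)cc2)[C@H](OC(C)=O)[C@@H](OC(C)=O)[C@@H]1OC(C)=O` is not yet measured. Compared with compound 2 the change is 4-(trifluoromethyl)phenyl in place of 3,4,5-trimethoxyphenyl on a double-bonded chain carbon bound to a double-bonded chain carbon. Within the data shown here, no measured pair shows what such a swap of the aromatic group does in this assay, and the absence of a number for compound 2 leaves no step to build on. The expectation for the step from compound 2 to compound 4 in this assay is therefore set at none beyond the usual scatter, with no direction preferred, and the estimate for compound 4 is instead anchored on compound 1.

Compound 4 is expected to give about 5 nM in this assay, within a range from 1 nM to 30 nM, because compound 1 gives 4.17 nM with a different aromatic group on the same chain.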

Compound 4, half-maximal cytotoxic concentration: 103 nM
The estimate for compound 4 lay 21-fold (1.31 log units) below the measured number; the whole stated range lies below it.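

In this assay, among these compounds, 4-(trifluoromethyl)phenyl in place of pyridin-3-yl on a double-bonded chain carbon bound to a double-bonded chain carbon gives a 25-fold higher number from compound 1 to compound 4 (1.39 log units; beyond the scatter), the first readable evidence that the aromatic group at this position can shift how much compound is tolerated while the shared core stays the same. Among the compounds shown here, compound 2 and compound 3 have no reported number, so the steps linking either of them to compound 4 cannot be read, and this single pair remains the only measured comparison at this position. Nothing available bears on why this exchange raises the number.

The compounds shown leave open whether the shift follows from the arrival of the trifluoromethyl group, from the departure of the pyridine nitrogen, or from both, since the two changes occur together in this one step. A plain phenyl group at the same position would separate those two contributions, and an amine or a carboxylic acid on that ring would show whether the number moves in the same direction with substituents of a different kind.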